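Chlorophenyl Shift Read Across Two Related Cores

The source may hold more compounds than are shown below. What is called first, only, known or untested is meant among the compounds shown, and "the series" means these compounds.

Compound 1 `O=C(NNc1ccccc1Cl)c1ccc(NS(=O)(=O)c2cnc(O)nc2O)cc1` and compound 2 `O=C(NNc1cccc(Cl)c1)c1ccc(NS(=O)(=O)c2cnc(O)nc2O)cc1` share one core, and compound 3 `O=C(NNc1ccccc1Cl)c1ccccc1NS(=O)(=O)c1cnc(O)nc1O` and compound 4 `O=C(NNc1cccc(Cl)c1)c1ccccc1NS(=O)(=O)c1cnc(O)nc1O` share another; the difference between the two cores is not broken down here. Within the first pair, the change is 3-chlorophenyl in place of 2-chlorophenyl on an amine nitrogen. In a functional assay on SGC-7901 cells (Homo sapiens) for antiproliferative activity, read by MTT assay, with a stated time of 24 h (a higher number here means a weaker inhibitor, a lower number a stronger inhibitor), compound 1 gives 3630 nM. In this assay compound 2 gives 11600 nM, so the change produced a 3.2-fold higher number from compound 1 to compound 2 (0.50 log units; beyond the scatter).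

Compound 3 reaches only a limit in this assay, reported as > 20000 nM. This is the limit at which one of the three measured values sits (the limit of > 20000 nM in this assay, at which 1 of the 3 values shown sits).

Compound 4 carries the same change on the second core, 3-chlorophenyl in place of 2-chlorophenyl on an amine nitrogen, and the surroundings of the place are the same in both pairs. Because compound 3 already sits at the limit > 20000 nM, and because the same change gave a 3.2-fold higher number from compound 1 to compound 2 (0.50 log units; beyond the scatter), compound 4 is expected to remain outside the measurable range, with an expected step that the limit leaves unreadable from compound 3 to compound 4. The estimate for compound 4 in this assay is 45000 nM, expected to lie between 20000 nM and 120000 nM, and the most likely outcome is that only a limit is reported again.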

Compound 4, half-maximal inhibitory concentration: 10800 nM
The estimate for compound 4 lay 4.2-fold (0.62 log units) above the measured number; measured number outside the range, below it.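

In this assay compound 3 gives > 20000 nM, which is a limit of the assay and not a number. From the compounds shown here alone, measured against that limit, putting 3-chlorophenyl in place of 2-chlorophenyl on an amine nitrogen gives an at least 1.8-fold lower number from compound 3 to compound 4 (0.26 log units; that floor lies within the scatter), so the true size of this step on the second core stays unknown, and only its floor can be stated. The change therefore does not carry from one core to the other as a single fixed step, although one pair on each core cannot show how far the two steps really lie apart, nor whether the difference would hold for any further pair in this series:  the same change on two cores in this assay, a 3.2-fold higher number (0.50 log units; beyond the scatter) from compound 1 to compound 2 and an at least 1.8-fold lower number (0.26 log units; that floor lies within the scatter) from compound 3 to compound 4, at least 5.9-fold (0.77 log units) apart, beyond the scatter of two such steps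

Going by these compounds, what remains open is whether a plain phenyl group or a methoxyphenyl group in the same place on an amine nitrogen would follow the step seen on the core of compound 1 or the one seen on the core of compound 3. The compounds shown also leave open which part of the difference between the two cores decides how this change reads out, as that difference is not broken down into single changes here.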